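The source may report more compounds than this note shows. Statements on the series, on what has been measured and on what is new or still open speak of the compounds shown alone.

Three compounds of the series have been run in a functional assay on QGY7701 cells (Homo sapiens) for cytotoxicity, read by MTT assay, with a stated time of 24 h; on this read-out higher numbers stand for weaker inhibition and lower numbers for stronger inhibition. Compound 1 `C=CC1=C(C(=O)NCc2ccc(Cl)cc2)C(c2ccc(OC)c(OC)c2)OC1` returns only the limit of the assay, > 100000 nM, in this assay. Compound 2 `C=CC1=C(C(=O)NCc2ccc(Cl)cc2)C(c2ccc(OC)cc2)OC1` likewise returns only the limit, > 100000 nM, in this assay. Compound 3 `C=CC1=C(C(=O)NCCC)C(c2ccc(Cl)c(Cl)c2)OC1` gives a number in this assay, 31300 nM. For the measured compounds named here, the one step between measured compounds that differ in one place runs from compound 1 to compound 2, hydrogen in place of methoxy on an aromatic carbon, and reads a step that the two limits leave unreadable from compound 1 to compound 2 since both compounds sit at the limit of > 100000 nM in this assay, at which 2 of the 3 values shown sit. Compound 2 therefore stands at the limit of this assay, with no number of its own to build on.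

Compound 4 `C=CC1=C(C(=O)NCC(C)C)C(c2ccc(OC)cc2)OC1` differs from compound 2 on the amide side: isopropyl in place of 4-chlorophenyl on a saturated chain carbon bound to an amide-type nitrogen. Going by the values given here, no measured step bears directly on this change. Compound 3 carries a propyl on the amide nitrogen and gives 31300 nM in this assay, but it also differs from compound 4 in the aryl ring, so its reading shows only that a small alkyl on the amide can come with a number rather than a limit. The step from compound 2 to compound 4 is expected to be an at least 1.4-fold lower number from compound 2 to compound 4 (0.15 log units; that floor lies within the scatter), toward a readable number, with wide uncertainty. Compound 4 is estimated at 70000 nM in this assay, between 25000 nM and 200000 nM.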

Compound 4, half-maximal inhibitory concentration: > 100000 nM
Compound 4: no number, only a limit; the forecaster's own chance of this, stated with the estimate: 50%; middle value at least 1.4-fold (0.15 log units) away from the limit.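

In this assay compound 4 gives > 100000 nM, which is a limit and not a number. Compound 2 also sits at a limit, so no step can be read between compound 2 and compound 4. The compounds shown leave open whether any change on the amide side alone, with the aryl ring held fixed, yields a readable number in this assay.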